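From 3-methoxyphenyl to 4-methoxyphenyl on a shared core

The source may report more compounds than this note shows. Statements on the series, on what has been measured and on what is new or still open speak of the compounds shown alone.

Compound 1 `COc1cc(C(=O)c2sc(-c3ccc([N+](=O)[O-])cc3)cc2N)cc(OC)c1OC`: 99 nM
Compound 2 `COc1cc(C(=O)c2sc(-c3ccc(Cl)c(Cl)c3)cc2N)cc(OC)c1OC`: 290 nM
Compound 3 `COc1cccc(-c2cc(N)c(C(=O)c3cc(OC)c(OC)c(OC)c3)s2)c1`: 16 nM

All three compounds were tested in a functional assay on CCRF-CEM cells (Homo sapiens) for antiproliferative activity; on this read-out higher numbers stand for weaker inhibition and lower numbers for stronger inhibition. Compound 3 has the lowest number of the three, and two measured steps separate it from the others: a 6.2-fold lower number from compound 1 to compound 3 (0.79 log units; beyond the scatter), and an 18-fold lower number from compound 2 to compound 3 (1.26 log units; beyond the scatter). The remaining step, a 2.9-fold higher number from compound 1 to compound 2 (0.47 log units; beyond the scatter), is at the same aromatic carbon.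

Compound 4 `COc1ccc(-c2cc(N)c(C(=O)c3cc(OC)c(OC)c(OC)c3)s2)cc1` has not yet been measured. It carries 4-methoxyphenyl in place of 3-methoxyphenyl on an aromatic carbon, next to the ring sulfur: 4-methoxyphenyl in place of 3-methoxyphenyl on an aromatic carbon. For the measured compounds named here, no measured pair isolates this swap, so the evidence is indirect. All three measured steps change the aryl group at this same carbon, and they range from modest to large, so a change here cannot be assumed to be silent. However, this swap keeps the methoxy group and alters only where it sits, so a large step seems less likely than the one from compound 2 to compound 3. Since compound 3 is the lowest so far, a modest rise is the most likely outcome. The expected step is a 1.8-fold higher number from compound 3 to compound 4 (0.24 log units; within the scatter), although a result within the scatter would not be surprising. For compound 4 the estimated value is 28 nM, with an expected range from 7 nM to 110 nM.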

Compound 4, half-maximal inhibitory concentration: 19 nM
Beside the measured number, compound 4's estimate is 1.5-fold (0.17 log units) above it, and the stated range covers the measured number.
By their numbers in this assay, from the lowest: compounds 3 and 4 (each within the scatter of the next); then compound 1; then compound 2.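

Moving the methoxy group around the phenyl ring, the one change that compound 4 isolates, leaves the number in this assay within the scatter (a 1.2-fold higher number from compound 3 to compound 4 (0.07 log units; within the scatter)), so at this carbon on the shared core, 3-methoxyphenyl and 4-methoxyphenyl cannot be told apart. For the compounds shown here, the earlier compounds showed only that exchanging one aryl group for a differently substituted one could shift the number; this pair shows that at least one such exchange does not. The distance from the other aryl groups also survives the move, with a 15-fold lower number from compound 2 to compound 4 (1.18 log units; beyond the scatter) and a 5.2-fold lower number from compound 1 to compound 4 (0.72 log units; beyond the scatter) both beyond the scatter, so compound 3 and compound 4 together stand apart from compound 1 and compound 2, and nothing at hand explains why the two methoxyphenyl groups read alike.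

The compounds shown leave open whether the methoxy group itself matters, since neither a plain phenyl nor a hydroxy group in its place appears among them. They also leave open whether a longer chain such as ethoxy, or an amine such as dimethylamino, would be tolerated on the phenyl ring at this carbon.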